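A few compounds are considered here, and "the series" means these few. Any claim that something is new, unique, unknown or untested is made for them only; others in the source may bear on it.

Compound 1 `Fc1ccc(Cc2ccc3c(NCCCNCc4ccco4)ccnc3c2)cc1` gives 5600 nM in an ADME assay on HepG2 cells (Homo sapiens) for cytotoxicity, read by luminescence, CellTiter-Glo and ATP content, with a stated time of 72 h; a higher number here means that more compound is needed for the effect, a lower number that less compound is needed. Compound 2 `COc1cccc(CNCCCNc2ccnc3cc(Cc4ccc(F)cc4)ccc23)c1O` gives 4780 nM in this assay. Compound 3 `FC(F)(F)c1cccc(Cc2ccc3c(NCCCNCc4ccco4)ccnc3c2)c1` gives 3190 nM in this assay.

Taken together, the three numbers sit close to one another. From compound 1 the two measured steps are a 1.2-fold lower number from compound 1 to compound 2 (0.07 log units; within the scatter) and a 1.8-fold lower number from compound 1 to compound 3 (0.24 log units; within the scatter); both fall within the scatter, so compound 1 cannot be separated from compound 2 or from compound 3 in this assay on these data, and the three compounds stand level.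

Compound 4 `c1coc(CNCCCNc2ccnc3cc(C4CCCCC4)ccc23)c1` has not yet been measured. It differs from compound 1 by cyclohexyl in place of 4-fluorobenzyl on an aromatic carbon. Among the measured compounds shown here, of the measured steps, the one from compound 1 to compound 3 touches the same group at the same aromatic carbon, exchanging one substituted phenyl for another, and it stayed within the scatter. The step from compound 1 to compound 2 alters the other end of the chain and also stayed within the scatter. For the measured compounds named here, no measured step removes the aromatic ring at this position entirely or swaps it for a saturated ring, so the change in compound 4 goes beyond what the measured pairs cover. With the two steps at hand both small, the expectation for compound 4 in this assay is a step of a 1.1-fold lower number from compound 1 to compound 4 (0.05 log units; within the scatter), that is, no change beyond the scatter. Compound 4 is therefore estimated at 5000 nM, with a range from 2000 nM to 15000 nM.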

Compound 4, half-maximal effective concentration: 4760 nM
Beside the measured number, compound 4's estimate is 1.1-fold (0.02 log units) above it, and the stated range covers the measured number.
By their numbers in this assay, from the lowest: compounds 3, 4, 2 and 1 (each within the scatter of the next).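

The exchange of 4-fluorobenzyl for cyclohexyl on this aromatic carbon gives a 1.2-fold lower number from compound 1 to compound 4 (0.07 log units; within the scatter) in this assay. The earlier step at this place only traded one substituted phenyl for another, whereas this one replaces the aromatic ring with a non-aromatic six-membered ring of carbon only and also removes the fluorine, and the result still stays within the scatter, so on this pair an aromatic ring at this position is not needed to keep the number level. Nothing available bears on why the number holds through this change.

All four compounds carry a six-membered ring of carbon only at this place, which leaves open what a methyl group, a morpholine or a carboxylic acid would do here. As far as these compounds go, it also remains open whether cyclohexyl behaves the same with the 2-hydroxy-3-methoxyphenyl group of compound 2 at the far end of the chain, and which change, if any, would move the number in this assay beyond the scatter.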